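Swapping methoxy for chloro on a thiourea macrophage-toxicity probe

The source may hold more compounds than are shown below. What is called first, only, known or untested is meant among the compounds shown, and "the series" means these compounds.

Of the compounds shown here, two sharing one core have been tested in an ADME assay on RAW264.7 cells (Mus musculus) for cytotoxicity, read by MTT assay, with a stated time of 48 h, tested at 50 uM; a higher number here means more inhibition at the concentration tested (going by the name of the read-out), a lower number less inhibition. Compound 1 `COc1ccc(CNC(=O)N2CCN(CCn3c(=O)ccc4ncc(OC)cc43)CC2)cc1` gives 37.6%. Compound 2 `COc1ccc(CNC(=S)N2CCN(CCn3c(=O)ccc4ncc(OC)cc43)CC2)cc1` carries a thiourea where compound 1 carries a urea. In this assay compound 2 gives 17.1%; this is the lower of the two numbers, and the gap to compound 1 lies beyond the usual scatter of repeated measurements.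

Compound 3 `COc1cnc2ccc(=O)n(CCN3CCN(C(=S)NCc4ccc(Cl)cc4)CC3)c2c1` has not yet been measured. Compared with compound 2, the change is chloro in place of methoxy on an aromatic carbon, a chloro in place of a methoxy on the aromatic carbon para to the large group. Among the measured compounds shown here, nothing among the measured pairs shows what this exchange does in this assay, so there is no measured step to lean on.

The expectation is that the step of a number 4.9 percentage points higher from compound 2 to compound 3 (within the scatter) stays within the scatter, in either direction. Compound 3 is therefore estimated at 22%, with a range from 8% to 40%.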

Compound 3, a percentage reported as inhibition, at one concentration (the size of the read-out at that concentration, not a potency): 25%
Compound 3: middle estimate off by 3 percentage points, on the low side, within the range that was stated.
By their numbers in this assay, from the lowest: compounds 2 and 3 (each within the scatter of the next); then compound 1.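

In this assay, going from 4-methoxybenzyl to 4-chlorobenzyl on the thiourea gives a number 7.9 percentage points higher from compound 2 to compound 3 (within the scatter). Among the compounds shown here, this is the first reading at this aromatic carbon, para to a large group, and it shows that chloro can take the place of methoxy here without a change that can be told apart from the scatter, whereas the earlier urea and thiourea pair differed beyond it. Nothing available explains why these two groups read alike.

One pair cannot show whether this position is insensitive in general, or whether an amine or a carboxylic acid on the same carbon would read the same. On these data alone, it also remains open whether chloro would behave the same way on the urea of compound 1.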